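Trading 2-Fluorobenzyl for tert-Butyl at Bombesin Receptor Subtype-3

The source may report more compounds than this note shows. Statements on the series, on what has been measured and on what is new or still open speak of the compounds shown alone.

Measured so far:
compound 1, `O=C(O)c1ccccc1-c1ccc(CCc2ncc(Cc3ccccc3F)[nH]2)cc1`: 177 nM
compound 2, `CCC(C)(C)Cc1c[nH]c(CCc2ccc(-c3ccccc3C(=O)O)cc2)n1`: 25 nM

Both compounds were tested in an in vitro functional assay on cells for agonist activity at Bombesin receptor subtype-3 (Homo sapiens), read by luminescence and calcium flux; a higher number here means that more compound is needed for the effect, a lower number that less compound is needed. Compound 1 stands with the highest of the two numbers; compound 2 gives a lower one, and the gap between them lies beyond the scatter. Compound 3, `CC(C)(C)c1cnc(CCc2ccc(-c3ccccc3C(=O)O)cc2)[nH]1`, differs from compound 1 by tert-butyl in place of 2-fluorobenzyl on an aromatic carbon, a tert-butyl in place of 2-fluorobenzyl on an aromatic carbon. Compound 2 likewise carries no second aromatic ring on that carbon and gives 25 nM, so a clear drop in the number is expected, a 3.0-fold lower number from compound 1 to compound 3 (0.47 log units; beyond the scatter), though the tert-butyl is smaller than the group in compound 2. For compound 3 the expected value is 60 nM, between 20 nM and 180 nM.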

Compound 3, half-maximal effective concentration: 4330 nM
Beside the measured number, compound 3's estimate is 72-fold (1.86 log units) below it; the measured number lies above the stated range.
By their numbers in this assay, from the lowest: compound 2; then compound 1; then compound 3.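

In this assay, tert-butyl in place of 2-fluorobenzyl on this aromatic carbon gives a 24-fold higher number from compound 1 to compound 3 (1.39 log units; beyond the scatter) and so shows that removing the second aromatic ring does not by itself lower the number. Compound 2, also without an aromatic ring on that carbon, gives 25 nM while compound 3 gives 4330 nM and so this position separates even groups without a ring. Nothing shown here bears on the reason for this loss. Still open, on these data alone, is how a plain benzyl or a cyclohexylmethyl group on this carbon would compare.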